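The compounds below may be only part of what the source reports. "The series", "measured", "known", "first", "only" and "open" are said of these compounds alone.

Compound 1 `Cc1ccc(-n2cc(CNC(=O)c3cccc4c3cnn4C(C)C)nn2)cc1C`: 23400 nM
Compound 2 `Cc1ccccc1-n1cc(CNC(=O)c2cccc3c2cnn3C(C)C)nn1`: 19200 nM

In a functional assay on PC-3 cells (Homo sapiens) for inhibition, read by MTT assay, with a stated time of 72 h (a higher number here means a weaker inhibitor, a lower number a stronger inhibitor), compound 2 gives 19200 nM. Among the measured compounds shown here, the only measured step, a 1.2-fold lower number from compound 1 to compound 2 (0.09 log units; within the scatter), is within the scatter, so the two compounds cannot be told apart on these numbers. Compound 3 `COc1ccc(-n2cc(CNC(=O)c3cccc4c3cnn4C(C)C)nn2)cc1` differs from compound 2 by 4-methoxyphenyl in place of 2-methylphenyl on an aromatic nitrogen. For the measured compounds named here, the single step on this aromatic nitrogen, from compound 1 to compound 2, stayed within the scatter, and nothing beyond the scatter is therefore expected here either. Compound 3 is estimated at 20000 nM, with a range from 8000 nM to 50000 nM. This amounts to an expected step of a 1.0-fold higher number from compound 2 to compound 3 (0.02 log units; within the scatter).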

Compound 3, half-maximal inhibitory concentration: 34300 nM
Compound 3: middle estimate off by 1.7-fold (0.23 log units), on the low side; low and high end bracket the measured number.
By their numbers in this assay, from the lowest: compounds 2, 1 and 3 (each within the scatter of the next).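

In this assay, a first substituent with an oxygen, 4-methoxyphenyl, which carries a hydrogen-bond acceptor that 2-methylphenyl lacks, gives a 1.8-fold higher number from compound 2 to compound 3 (0.25 log units; within the scatter) and a 1.5-fold higher number from compound 1 to compound 3 (0.17 log units; within the scatter). So on this aromatic nitrogen, neither swapping the methyl-bearing phenyl groups nor adding this oxygen separates the compounds beyond the scatter. No measurement at hand explains these numbers.

From the compounds shown here alone, whether any group here can move the number beyond the scatter stays open, for example a phenyl ring bearing an amine or a carboxylic acid, or a longer chain in place of the ring.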